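The compounds below may be only part of what the source reports. "The series", "measured", "known", "first", "only" and "open" are said of these compounds alone.

Measured in a functional assay on MDA-MB-231 cells (Homo sapiens) for antiproliferative activity, read by sulforhodamine B assay; a lower number here means a stronger inhibitor of growth, a higher number a weaker inhibitor of growth:
- Compound 1 `CC(C)(C)CCOc1cccc(O)c1C(=O)/C=C/c1ccc(O)cc1`: 2380 nM.
- Compound 2 `O=C(/C=C/c1ccc(O)cc1)c1c(O)cccc1OCCC1CCCCC1`: > 30000 nM, a limit and not a number.
- Compound 3 `O=C(/C=C/c1ccc(O)cc1)c1c(O)cccc1OCC1CCCCC1`: > 30000 nM, also a limit and not a number.

Compound 2 therefore has no number to stand on, only (the limit of > 30000 nM in this assay, at which 2 of the 3 values shown sit). Compound 3 gives no help in placing it, as a step that the two limits leave unreadable from compound 2 to compound 3 shows. The change under consideration leads to compound 4 `CC(C)COc1cccc(O)c1C(=O)/C=C/c1ccc(O)cc1` and is isopropyl in place of cyclohexylmethyl on a saturated chain carbon bound to an oxygen on an aromatic ring.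

Within the data shown here, two measured steps bear on this change. Both start from compound 1, which has no ring in its chain, and both end at a compound with a cyclohexyl group: an at least 12-fold higher number from compound 1 to compound 2 (1.10 log units; beyond the scatter) and an at least 12-fold higher number from compound 1 to compound 3 (1.10 log units; beyond the scatter). Both are large. Removing the ring from compound 2 should therefore reverse much of that loss in this assay. The expected step is an at least 6.0-fold lower number from compound 2 to compound 4 (0.77 log units; beyond the scatter), a large one towards a lower number. Compound 4 is estimated at 5000 nM, with an expected range of 1500 nM to 20000 nM.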

Compound 4, concentration for 50% growth inhibition: 3520 nM
Estimate against measurement, compound 4: 1.4-fold (0.15 log units) above; measured number inside the range.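

In this assay, the ring-free isopropyl group on a saturated chain carbon bound to an oxygen on an aromatic ring gives a clear gain over the cyclohexyl-bearing chains: an at least 8.5-fold lower number from compound 2 to compound 4 (0.93 log units; beyond the scatter), and an at least 8.5-fold lower number from compound 3 to compound 4 (0.93 log units; beyond the scatter). Among the ring-free chains, the change at this place reads differently, with a 1.5-fold higher number from compound 1 to compound 4 (0.17 log units; within the scatter), so isopropyl and neopentyl cannot be told apart here, and across the four compounds only the two with a cyclohexyl ring lose measurable activity. Compound 2 and compound 3 each stand at a limit and not a number, so the full size of the gain stays unknown: the limit of > 30000 nM in this assay, at which 2 of the 4 values shown sit.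

The compounds shown leave open whether the cyclohexyl ring as such matters or only the larger count of heavy atoms. A cyclopropylmethyl group, a phenyl group or an amine on the chain would begin to separate these.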